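This account rests on a few compounds, and the source may have more. Where it says the series, first, only, none or still open, it means among the compounds named here.

Four compounds share one core. Compound 1 `CC(C)(C)c1cc(NC(=O)[C@@H]2CCCCN2Cc2ccc(Cl)cc2)no1` carries a 4-chlorobenzyl group on the ring nitrogen, compound 2 `CC(C)(C)c1cc(NC(=O)[C@@H]2CCCCN2CC2CCOCC2)no1` an (oxan-4-yl)methyl group, and compound 3 `CC(C)(C)c1cc(NC(=O)[C@@H]2CCCCN2C(=O)N2CCOCC2)no1` a (morpholin-4-yl)carbonyl group. In a physicochemical assay for solubility, read by HPLC, at pH 6.8 (on this read-out lower numbers stand for lower solubility and higher numbers for higher solubility), compound 1 sits at a limit of the assay, < 0.1 ug/mL. Compound 2 gives 72 ug/mL and compound 3 gives 45 ug/mL, a step of a 1.6-fold lower number from compound 2 to compound 3 (0.20 log units; within the scatter), so these two cannot be told apart. Compound 4 `CC(C)(C)c1cc(NC(=O)[C@@H]2CCCCN2C(=O)N2CCSCC2)no1` is the partner not yet measured: (thiomorpholin-4-yl)carbonyl in place of (oxan-4-yl)methyl on an amine nitrogen in a ring. Within the data shown here, the only measured step of the same kind stayed within the scatter, a 1.6-fold lower number from compound 2 to compound 3 (0.20 log units; within the scatter), and nothing here points to a larger move. Because that step a 1.6-fold lower number from compound 2 to compound 3 (0.20 log units; within the scatter) was small, compound 4 is expected to show a step of about a 2.1-fold lower number from compound 2 to compound 4 (0.31 log units; beyond the scatter). Compound 4 is therefore estimated at 35 ug/mL, between 10 ug/mL and 110 ug/mL.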

Compound 4, solubility: 46 ug/mL
Beside the measured number, compound 4's estimate is 1.3-fold (0.12 log units) below it; the measured number falls inside the stated range.
By their numbers in this assay, from the lowest: compounds 3, 4 and 2 (each within the scatter of the next). At a limit, below all of these: compound 1.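

In this assay, thiomorpholin-4-yl in place of morpholin-4-yl on a carbonyl carbon gives a 1.0-fold higher number from compound 3 to compound 4 (0.01 log units; within the scatter), so the sulfur-containing ring cannot be told apart from its oxygen-containing partner, and the comparison with the group without a carbonyl gives a 1.6-fold lower number from compound 2 to compound 4 (0.19 log units; within the scatter). Compound 4 also joins the large jump away from the 4-chlorobenzyl compound, with an at least 460-fold higher number from compound 1 to compound 4 (2.66 log units; beyond the scatter). That step rests on a limit of the assay, not on a number: the limit of < 0.1 ug/mL in this assay, at which 1 of the 4 values shown sits.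

Still open, from the compounds shown here alone, is where a piperazin-1-yl group on the carbonyl would fall. An unsubstituted benzyl group or a carboxylic acid on the (oxan-4-yl)methyl group also remains to be placed.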